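Trading a substituted phenyl for a small pyrimidine

A few compounds are considered here, and "the series" means these few. Any claim that something is new, unique, unknown or untested is made for them only; others in the source may bear on it.

The compounds here share one core, and they were tested in a functional assay on cells for agonist activity at Free fatty acid receptor 1 (Rattus norvegicus), read by FLIPR and calcium flux; a higher number here means that more compound is needed for the effect, a lower number that less compound is needed. Compound 1, with the structure `CC#C[C@@H](Cc1nnn[nH]1)c1ccc(OCc2ccc3scc(-c4cc(OCCOC)ccc4C)c3c2)cc1`, gives 26 nM. Compound 2, with the structure `CC#C[C@@H](Cc1nnn[nH]1)c1ccc(OCc2cc(F)c3scc(-c4ccc(OC)cc4C)c3c2)cc1`, gives 39 nM. These two numbers sit within the scatter of each other, so nothing separates compound 1 from compound 2 on this evidence; compound 1 simply has the smaller of the two numbers, and the two differ in more than one place, so no single change can be read from them.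

Compound 3, with the structure `CC#C[C@@H](Cc1nnn[nH]1)c1ccc(OCc2ccc3scc(-c4cncnc4C)c3c2)cc1`, has not yet been measured. It departs from compound 1 as follows: 4-methylpyrimidin-5-yl in place of 5-(2-methoxyethoxy)-2-methylphenyl on an aromatic carbon. The group that leaves is larger than the one that enters, and the ring that enters carries two nitrogens where the old ring had none.

Among the measured compounds shown here, no measured pair shows what this kind of swap does. The expectation is that compound 3 will need somewhat more compound than compound 1, with a step of a 2.3-fold higher number from compound 1 to compound 3 (0.36 log units; beyond the scatter). Compound 3 is therefore estimated at 60 nM, within a range from 20 nM to 200 nM.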

Compound 3, half-maximal effective concentration: 18 nM
The estimate for compound 3 lay 3.3-fold (0.52 log units) above the measured number, and the stated range ends above it.
By their numbers in this assay, from the lowest: compounds 3, 1 and 2 (each within the scatter of the next, the first and the last beyond it).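

At this position, on an aromatic carbon of a five-membered aromatic ring with 1 sulfur, a group of 12 heavy atoms gives way to one of 7, and this assay records a 1.4-fold lower number from compound 1 to compound 3 (0.16 log units; within the scatter), so compound 1 and compound 3 cannot be told apart on this evidence. Among the compounds shown here, this is the first single change in the set, and it shows that the 5-(2-methoxyethoxy)-2-methylphenyl group is not needed at this position to keep the number in the same range: 4-methylpyrimidin-5-yl, a smaller ring with 2 hetero atoms and no ether chain, serves there as well in this one pair. Nothing measured here explains why the number holds when so much of the group is replaced.

As far as these compounds go, the swap changes the ring and removes the 2-methoxyethoxy chain in a single step, so the effect of each part on its own stays open. A plain 2-methylphenyl group, a methylpyridine ring, or a pyrimidine carrying a 2-methoxyethoxy chain at this position would be needed to pull those two parts apart.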